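Compound 3 to compound 4: methoxy swapped for methyl

A few compounds are considered here, and "the series" means these few. Any claim that something is new, unique, unknown or untested is made for them only; others in the source may bear on it.

Measured so far in a functional assay on PC-3 cells (Homo sapiens) for cytotoxicity, read by MTT assay, with a stated time of 72 h; a lower number here means a stronger inhibitor, a higher number a weaker inhibitor (lower means stronger):
- Compound 1 (`c1ccc2[nH]c(-n3cccn3)cc2c1`) gives > 100000 nM (a limit, not a number)
- Compound 2 (`COc1ccc2[nH]c(-c3ccc[nH]3)cc2c1`) gives 26000 nM (a number)
- Compound 3 (`COc1ccc2[nH]c3c4cn[nH]c4c4c(c3c2c1)C(=O)NC4=O`) gives > 100000 nM (a limit, not a number)

Going by the values given here, compound 3 has no numerical reading in this assay and stands only at its limit of > 100000 nM (the sole result for this compound). The set as a whole sits largely at one ceiling, which is the limit of > 100000 nM in this assay, at which 2 of the 3 values shown sit (compound 3 is one of those two).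

Compound 4 (`Cc1ccc2[nH]c3c4cn[nH]c4c4c(c3c2c1)C(=O)NC4=O`) keeps the core of compound 3 and carries methyl in place of methoxy on an aromatic carbon on a six-membered aromatic ring of carbon only, part of a fused or bridged system of five rings. Among the compounds with values here, no measured pair here isolates this change, so its size cannot be read from the data. Only a small step is expected, with no firm direction, and compound 4 is expected to stay close to the ceiling of this assay and may well return only a limit.

The expected change is an at least 1.2-fold lower number from compound 3 to compound 4 (0.09 log units; that floor lies within the scatter) (an estimate set against a limit, so it is rough).

The estimated value for compound 4 is 80000 nM (expected range 25000 nM to 150000 nM).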

Compound 4, half-maximal inhibitory concentration: > 100000 nM
Compound 4 was reported as a limit (the forecaster's own chance of this, stated with the estimate: 65%); at least 1.2-fold (0.09 log units) between middle value and limit.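

Compound 3 and compound 4 are each reported only as a limit in this assay, so swapping methoxy for methyl gives no readable step. Both results rest at the same ceiling: the limit of > 100000 nM in this assay, at which 3 of the 4 values shown sit.

The compounds shown leave open whether any group on this aromatic carbon of the shared core would give a numerical reading in this assay.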